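The source may hold more compounds than are shown below. What is called first, only, known or untested is meant among the compounds shown, and "the series" means these compounds.

- Compound 1 `CC(C)(C)Sc1c(CC(C)(C)C(=O)O)n(Cc2ccc(Cl)cc2)c2ccc(OCc3cc4ccccc4cn3)cc12`: 3 nM
- Compound 2 `CC(C)(C)Sc1c(CC(C)(C)C(=O)O)n(Cc2ccc(Cl)cc2)c2ccc(OCc3nc4ccccc4o3)cc12`: < 7 nM (a limit, not a number)
- Compound 3 `C[C@H](COc1ccc2c(c1)c(SC(C)(C)C)c(CC(C)(C)C(=O)O)n2Cc1ccc(Cl)cc1)c1ccccn1`: 3 nM

These values come from a functional assay for inhibition, with Homo sapiens as the target; a lower number here means a stronger inhibitor, a higher number a weaker inhibitor. Compound 3 stands level with compound 1 at the digits shown. Compound 4 `CC(C)(C)Sc1c(CC(C)(C)C(=O)O)n(Cc2ccc(Cl)cc2)c2ccc(OCc3cccs3)cc12` has not yet been measured, and it differs from compound 3 by one swap: thiophen-2-yl in place of 1-(pyridin-2-yl)ethyl on a saturated chain carbon bound to an oxygen on an aromatic ring. Two measured steps changed the group at this same place, on a saturated chain carbon bound to an oxygen on an aromatic ring. The readable one is no change at the digits printed from compound 1 to compound 3 (within the scatter). The other is a step that the limit leaves unreadable from compound 1 to compound 2. Three quite different groups thus leave no readable loss, so no step beyond the scatter is expected here. The expected change is a 1.7-fold higher number from compound 3 to compound 4 (0.22 log units; within the scatter). For compound 4 the estimated value is 5 nM, with an expected range of 2 nM to 15 nM.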

Compound 4, half-maximal inhibitory concentration: 4 nM
The estimate for compound 4 lay 1.3-fold (0.10 log units) above the measured number; the measured number falls inside the stated range.
By their numbers in this assay, from the lowest: compounds 1, 3 and 4 (each within the scatter of the next).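

Thiophen-2-yl, with 5 heavy atoms, sulfur in place of nitrogen and no defined stereocentre, gives a 1.3-fold higher number from compound 3 to compound 4 (0.12 log units; within the scatter), and against isoquinolin-3-yl it gives a 1.3-fold higher number from compound 1 to compound 4 (0.12 log units; within the scatter). In this assay, then, a ring nitrogen and a defined stereocentre in this group are not needed to stay within the scatter at this place. Compound 2 carries a limit, not a number, so the steps to it cannot be read: the limit of < 7 nM in this assay, at which 1 of the 4 values shown sits.

On these data alone, whether this holds for groups without a ring, such as a plain methyl or a chain ending in an amine, remains open.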